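Pyrazole carboxamide series: acylamino replacement on compound 2

The source may hold more compounds than are shown below. What is called first, only, known or untested is meant among the compounds shown, and "the series" means these compounds.

Measured so far in an assay on CHO-K1 cells for displacement of a labelled ligand from prostaglandin E2 receptor EP1 subtype (Homo sapiens); on this read-out lower numbers stand for stronger inhibition and higher numbers for weaker inhibition:
- compound 1 `Cc1cc(C(N)=O)nn1Cc1cc(Cl)ccc1OCc1ccccc1` gives 126 nM
- compound 2 `Cc1cc(C(N)=O)nn1Cc1cc(Cl)ccc1OCC(C)C` gives 126 nM
- compound 3 `CC(=O)Nc1cc(C)n(Cc2cc(Cl)ccc2OCc2ccccc2)n1` gives 316 nM

Compound 2 stands level with compound 1 at the digits shown, no change at the digits printed from compound 1 to compound 2 (within the scatter), and the two together are the lowest numbers of the three; its furthest neighbour is compound 3, which differs from compound 1 by a 2.5-fold higher number from compound 1 to compound 3 (0.40 log units; beyond the scatter).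

Compound 4 `Cc1cc(NC(=O)C2CCCCC2)nn1Cc1cc(Cl)ccc1OCC(C)C` is not yet measured. It differs from compound 2 in one place: (cyclohexylcarbonyl)amino in place of carbamoyl on an aromatic carbon. Among the compounds with values here, the only measured step that bears on this change is the one from compound 1 to compound 3, where acetamido replaced carbamoyl on the same aromatic carbon and gave a 2.5-fold higher number from compound 1 to compound 3 (0.40 log units; beyond the scatter). Compound 4 carries a cyclohexylcarbonylamino group in that position, so a step of at least that modest size in the weaker direction is expected, with the wider ring-bearing group adding uncertainty. The expected step is a 3.2-fold higher number from compound 2 to compound 4 (0.50 log units; beyond the scatter). Compound 4 is therefore estimated at 400 nM in this assay, with a range from 130 nM to 1300 nM.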

Compound 4, half-maximal inhibitory concentration: 31.6 nM
For compound 4 the middle estimate is 13-fold (1.10 log units) above the measured one, and the stated range ends above it.
By their numbers in this assay, from the lowest: compound 4; then compounds 1 and 2 (each within the scatter of the next); then compound 3.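

In this assay, the step of a 4.0-fold lower number from compound 2 to compound 4 (0.60 log units; beyond the scatter) shows that an acylamino group on this aromatic carbon can lower the number relative to carbamoyl, whereas acetamido gave a 2.5-fold higher number from compound 1 to compound 3 (0.40 log units; beyond the scatter) and suggested only a loss. The two steps run in opposite directions, but they differ in the acyl group and also in the ether chain, which ends in phenyl in compounds 1 and 3 and in isopropyl in compounds 2 and 4. No measurement available here gives a reason for the lower number.

From the compounds shown here alone, it remains open whether the change of direction belongs to the cyclohexane ring or to its pairing with the isopropyl-ended chain, as each acylamino group appears with only one ether chain. Also open, going by these compounds, is how a longer open chain such as pentanoylamino, or a benzoylamino group, would compare on the core of compound 2.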